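The source may report more compounds than this note shows. Statements on the series, on what has been measured and on what is new or still open speak of the compounds shown alone.

Of the compounds shown here, two with a shared core have been measured in an assay on HEK293 cells for agonist activity at transient receptor potential cation channel subfamily M member 8 (Homo sapiens), read by fluorescence and calcium flux, with a stated time of 15 min; on this read-out higher numbers stand for an effect only at larger amounts of compound and lower numbers for an effect already at smaller amounts. Compound 1 `CCN(Cc1ccc(C)s1)C(=O)COc1ccc(C)cc1` gives 178 nM in this assay, while compound 2 `Cc1ccc(OCC(=O)N(Cc2cccs2)CC(C)C)cc1` gives 900 nM. Of the two numbers, compound 2 holds the higher one, and the gap down to compound 1 lies beyond the usual scatter, so compound 2 acts only at the larger amount of the pair. The two structures differ in more than one place, so no single change can be read from their values.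

Compound 3 `Cc1ccc(OCC(=O)N(Cc2cccs2)C2CC2)cc1` has not yet been measured. It keeps the core of compound 2 and changes one group: cyclopropyl in place of isobutyl on an amide-type nitrogen. Within the data shown here, no measured pair shows the effect of such a swap, so the expectation rests on the size of the change alone. A step of moderate size toward a lower number is expected, giving a 1.8-fold lower number from compound 2 to compound 3 (0.26 log units; within the scatter) for compound 3 in this assay. On that basis compound 3 is estimated at 500 nM, with a range from 200 nM to 1500 nM.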

Compound 3, half-maximal effective concentration: 8 nM
For compound 3 the middle estimate is 63-fold (1.80 log units) above the measured one; the whole stated range lies above it.
By their numbers in this assay, from the lowest: compound 3; then compound 1; then compound 2.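

In this assay the group on the amide-type nitrogen turns out to be a place where a small edit counts for a great deal: cyclopropyl in place of isobutyl gives a 110-fold lower number from compound 2 to compound 3 (2.05 log units; beyond the scatter) and so brings an effect at far smaller amounts of compound. Both groups are made of carbon only, with no hydrogen-bond donors or acceptors and no net charge, and the entering group carries a three-membered ring, so a change that looks modest on paper can go with a very large step at this position. Nothing available here explains why the step is so large.

Going by these compounds, it stays open whether the three-membered ring itself is what counts or whether a smaller carbon group would do the same, and an isopropyl group or a cyclobutyl group on the same nitrogen would help to separate the two. Also open, on these data alone, is whether the same swap would act alike on the core of compound 1, which differs from compound 2 and compound 3 in more than one place and so cannot be used to test this change.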